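The compounds below may be only part of what the source reports. "The series", "measured", "known", "first", "only" and "open" are said of these compounds alone.

In a functional assay on OVCAR-5 cells (Homo sapiens) for inhibition (a lower number here means a stronger inhibitor of growth, a higher number a weaker inhibitor of growth), compound 1 `Nc1ccc(-c2nc3cc(F)ccc3s2)cc1` gives 29500 nM. Compound 2 `Nc1ccc(-c2nc3cc(F)ccc3s2)cc1Cl` gives < 10 nM, and this is a limit of the assay, not a number. Compound 2 therefore stands at the limit of < 10 nM in this assay, at which 1 of the 2 values shown sits. Compound 3 `Nc1ccc(-c2nc3cc(F)ccc3s2)cc1I` makes one further change: iodo in place of chloro on an aromatic carbon. The new group is iodo in place of chloro, ortho to an amino group. Among the measured compounds shown here, only one measured step bears on this, the arrival of chloro in place of hydrogen, and it is large: an at least 2900-fold lower number from compound 1 to compound 2 (3.46 log units; beyond the scatter). Compound 3 also carries a group other than hydrogen on that carbon, so most of the gain seen in an at least 2900-fold lower number from compound 1 to compound 2 (3.46 log units; beyond the scatter) is expected to remain. That step says nothing direct about iodo against chloro, and no shift beyond the scatter is expected. The estimated step in this assay is a number no lower from compound 2 to compound 3 (the limit leaves the size open). Compound 3 is estimated at 10 nM, with an expected range of 2 nM to 80 nM.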

Compound 3, concentration for 50% growth inhibition: 280 nM
For compound 3 the middle estimate is 28-fold (1.45 log units) below the measured one, outside the stated range (above it).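

On this carbon, ortho to an amino group, the kind of group matters and not only its presence: in this assay, iodo in place of chloro gives a clearly weaker inhibitor of growth (an at least 28-fold higher number from compound 2 to compound 3 (1.44 log units; beyond the scatter)). Iodo still keeps a large part of the gain over hydrogen (a 110-fold lower number from compound 1 to compound 3 (2.02 log units; beyond the scatter)), so both compounds carrying a group here beat compound 1, but the two groups are not interchangeable. For compound 2 the value is a limit of the assay and not a number: (the limit of < 10 nM in this assay, at which 1 of the 3 values shown sits)

The compounds shown leave open how fluoro, bromo or a methyl group would fare on this carbon, and whether the order seen for chloro and iodo would extend to them. They also do not tell what separates iodo from chloro, as the two are counted alike in heavy atoms, donors and acceptors.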